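The source may report more compounds than this note shows. Statements on the series, on what has been measured and on what is new or still open speak of the compounds shown alone.

Three compounds share one core and differ only in the group on an amine nitrogen in a ring. In a functional assay on HCT-116 cells (Homo sapiens) for antiproliferative activity, read by MTT assay, with a stated time of 72 h (on this read-out lower numbers stand for stronger inhibition and higher numbers for weaker inhibition), compound 1 `Nc1nc(N)c2cc(CSC(=S)N3CCN(C4CCCCC4)CC3)ccc2n1` gives 8400 nM, the highest of the three numbers. Compound 2 `Nc1nc(N)c2cc(CSC(=S)N3CCN(c4ccc(Cl)c(Cl)c4)CC3)ccc2n1` gives 6680 nM, and compound 3 `Nc1nc(N)c2cc(CSC(=S)N3CCN(c4ccc(F)cc4)CC3)ccc2n1` gives 3270 nM. The step of a 1.3-fold lower number from compound 1 to compound 2 (0.10 log units; within the scatter) stays within the scatter, while a 2.6-fold lower number from compound 1 to compound 3 (0.41 log units; beyond the scatter) is a modest lowering. Compound 4 `Nc1nc(N)c2cc(CSC(=S)N3CCN(c4ccccn4)CC3)ccc2n1` has not been measured; it differs from compound 1 in one place: pyridin-2-yl in place of cyclohexyl on an amine nitrogen in a ring. Both earlier steps likewise replaced the cyclohexyl with a six-membered ring group and gave numbers no higher than compound 1. A similar outcome is expected here, so compound 4 is expected to show a 1.9-fold lower number from compound 1 to compound 4 (0.27 log units; within the scatter). Compound 4 is therefore estimated at 4500 nM, with a range from 2000 nM to 10000 nM.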

Compound 4, half-maximal inhibitory concentration: 5960 nM
The estimate for compound 4 lay 1.3-fold (0.12 log units) below the measured number; low and high end bracket the measured number.
By their numbers in this assay, from the lowest: compounds 3, 4, 2 and 1 (each within the scatter of the next, the first and the last beyond it).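

Swapping cyclohexyl for pyridin-2-yl on this amine nitrogen brings in a ring nitrogen and a hydrogen-bond acceptor, yet in this assay it gives only a 1.4-fold lower number from compound 1 to compound 4 (0.15 log units; within the scatter). Compared with the other aromatic groups, the steps are a 1.8-fold higher number from compound 3 to compound 4 (0.26 log units; within the scatter) and a 1.1-fold lower number from compound 2 to compound 4 (0.05 log units; within the scatter), so compound 4 cannot be ranked against any of the other three compounds. No measured evidence accounts for these results. Going by these compounds, whether pyridin-4-yl would give a similar number remains open. So does whether a simple methyl or a longer alkyl chain at this nitrogen would move the number beyond the scatter.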